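A second methoxy on the ring of compound 3

The source may report more compounds than this note shows. Statements on the series, on what has been measured and on what is new or still open speak of the compounds shown alone.

In a functional assay on K-562R cells (Homo sapiens) for cytotoxicity, read by MTT assay, with a stated time of 48 h (a lower number here means a stronger inhibitor, a higher number a weaker inhibitor), compound 1 (`COc1ccc(-c2c[nH]c(=O)n2-c2cc(OC)c(OC)c(OC)c2)cc1N`) reads > 50000 nM which is a limit of the assay and not a number. Compound 2 (`COc1cc(NC(=O)n2cc(-c3ccc(O)cc3)n(-c3cc(OC)c(OC)c(OC)c3)c2=O)cc(OC)c1OC`) also reads only a limit, > 50000 nM in this assay again. Compound 3 (`COc1ccc(-c2cn(C(=O)Nc3cc(OC)c(OC)c(OC)c3)c(=O)n2-c2cc(OC)c(OC)c(OC)c2)cc1`) gives 3500 nM and is the only one of the three with an actual number.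

Compound 4 (`COc1ccc(-c2cn(C(=O)Nc3cc(OC)c(OC)c(OC)c3)c(=O)n2-c2cc(OC)c(OC)c(OC)c2)cc1OC`) differs from compound 3 in one place (methoxy in place of hydrogen on an aromatic carbon). It has methoxy in place of hydrogen on an aromatic carbon, so 4-methoxyphenyl becomes 3,4-dimethoxyphenyl.

Among the measured compounds shown here, only one measured step touches this ring (an at least 14-fold lower number from compound 2 to compound 3 (1.15 log units; beyond the scatter)). There, methyl takes the place of hydrogen on an oxygen on the aromatic ring, and the step is large. Yet it is a different change from the one here, since compound 4 keeps that methoxy and gains a new one on a carbon. It therefore hints at a direction, towards a lower number, but says little about size. No step beyond the scatter is expected (a 1.2-fold lower number from compound 3 to compound 4 (0.07 log units; within the scatter)). The estimate for compound 4 is 3000 nM with an expected range from 700 nM to 15000 nM given how little evidence there is.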

Compound 4, half-maximal inhibitory concentration: > 50000 nM
Compound 4 was reported as a limit (the forecaster's own chance of this, stated with the estimate: 15%); middle value at least 16-fold (1.22 log units) away from the limit.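

Placing one methoxy on the aromatic carbon ortho to the existing methoxy, which turns 4-methoxyphenyl into 3,4-dimethoxyphenyl, gives an at least 14-fold higher number from compound 3 to compound 4 (1.15 log units; beyond the scatter) in this assay. Among the compounds shown here, the only earlier step on this ring was a change at the oxygen, not at a ring carbon, and it ran the other way, with an at least 14-fold lower number from compound 2 to compound 3 (1.15 log units; beyond the scatter); so this ring responds strongly to small changes at two different places, and a further methoxy on a ring carbon is not a harmless addition. Compound 3 is left as the only compound here with a real number, and everything else sits at one ceiling: the limit of > 50000 nM in this assay, at which 3 of the 4 values shown sit.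

From the compounds shown here alone, compound 4 reads > 50000 nM, which is a limit of the assay and not a number, so the true size of the loss stays unknown, and the step between compound 2 and compound 4 cannot be read at all. Going by these compounds, it also stays open whether the loss belongs to methoxy itself or to any group on this carbon, and a fluorine atom or a chlorine atom there would be the plainest test.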